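Fluoro for Chloro on the Core of Compound 2

The source may report more compounds than this note shows. Statements on the series, on what has been measured and on what is new or still open speak of the compounds shown alone.

Three compounds have been measured in an assay on isolated protein for displacement of a labelled ligand from metabotropic glutamate receptor 5 (Homo sapiens), with a stated time of 60 min, tested at 1 uM; a lower number here means less inhibition, a higher number more inhibition at the concentration tested (going by the name of the read-out):

compound 1, `CC1CCN(c2c(S(=O)(=O)c3ccc(Cl)c(Cl)c3)cnc3ccc(Cl)cc23)CC1`: 86%
compound 2, `CC1CCN(c2c(S(=O)(=O)c3cccc(Cl)c3)cnc3ccc(Cl)cc23)CC1`: 92%
compound 3, `CC1CCN(c2c(S(=O)(=O)c3ccc(F)c(F)c3)cnc3ccc(Cl)cc23)CC1`: 72%

Compound 2 carries the highest of the three numbers. Its nearest neighbour is compound 1, and the step of a number 6 percentage points higher from compound 1 to compound 2 (within the scatter) is too small to separate the two. Compound 3 lies furthest off, as the step of a number 20 percentage points lower from compound 2 to compound 3 (beyond the scatter) shows.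

Compound 4, `CC1CCN(c2c(S(=O)(=O)c3cccc(Cl)c3)cnc3ccc(F)cc23)CC1`, differs from compound 2 in one place: fluoro in place of chloro on an aromatic carbon. Among the compounds with values here, two measured steps concern an exchange of chlorine for fluorine, a number 14 percentage points lower from compound 1 to compound 3 (beyond the scatter) and a number 20 percentage points lower from compound 2 to compound 3 (beyond the scatter), but both sit on the ring bound to the sulfonyl sulfur, not on the core. Within the data shown here, no measured step touches the core position itself. Taking the two sulfonyl-ring steps as the only guide, a modest fall is expected, somewhat smaller than theirs since the change sits elsewhere; the step from compound 2 to compound 4 is estimated as a number 10 percentage points lower from compound 2 to compound 4 (within the scatter). For compound 4 the inhibition in this assay is estimated at 82%, with a range from 65% to 95%.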

Compound 4, a percentage reported as inhibition, at one concentration (the size of the read-out at that concentration, not a potency): 92%
Compound 4: the middle estimate sits 10 percentage points below what was measured; low and high end bracket the measured number.
By their numbers in this assay, from the lowest: compound 3; then compounds 1, 2 and 4 (each within the scatter of the next).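

In this assay, within the data shown here, fluoro in place of chloro on the aromatic carbon of the core gives no change at the digits printed from compound 2 to compound 4 (within the scatter), which is the first reading of this exchange at this position. The earlier exchanges of chlorine for fluorine lay on the ring bound to the sulfonyl sulfur, where the steps were a number 14 percentage points lower from compound 1 to compound 3 (beyond the scatter) and a number 20 percentage points lower from compound 2 to compound 3 (beyond the scatter), and the fall seen on that ring does not carry over to the core in this one pair. No measurement at hand gives a reason why the two places differ.

As far as these compounds go, what plain hydrogen, a methoxy group or a nitrile would do at this core position stays open, as does whether fluoro on the core and 3,4-difluorophenyl on the sulfonyl sulfur would behave the same way together. From the compounds shown here alone, since the read-out is a percentage at one concentration and not a potency, it also remains open whether compound 2 and compound 4 would separate in a full concentration series.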